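The source may report more compounds than this note shows. Statements on the series, on what has been measured and on what is new or still open speak of the compounds shown alone.

Measured in a functional assay on M21 cells (Homo sapiens) for inhibition, read by sulforhodamine B assay, with a stated time of 48 h; on this read-out higher numbers stand for weaker inhibition of growth and lower numbers for stronger inhibition of growth:
- compound 1 `c1cc(C2CCCCC2)ccc1NC1=NCCO1`: 17800 nM
- compound 2 `c1cc(OC2CCCC2)ccc1NC1=NCCO1`: 21100 nM

Within the data shown here, compound 2 stands level with compound 1, since the only measured step is a 1.2-fold higher number from compound 1 to compound 2 (0.07 log units; within the scatter). Compound 3 `c1cc(OC2CCCCC2)ccc1NC1=NCCO1` has cyclohexyl in place of cyclopentyl on an oxygen on an aromatic ring. Among the measured compounds shown here, no measured step changes this ring alone, so the evidence is indirect, but the one neighbouring step stayed small. No change beyond the scatter is therefore expected in this assay. The estimated step is a 1.1-fold lower number from compound 2 to compound 3 (0.05 log units; within the scatter). Compound 3 is expected at about 19000 nM, within an estimated range of 10000 nM to 35000 nM.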

Compound 3, concentration for 50% growth inhibition: 20800 nM
The estimate for compound 3 lay 1.1-fold (0.04 log units) below the measured number; low and high end bracket the measured number.
By their numbers in this assay, from the lowest: compounds 1, 3 and 2 (each within the scatter of the next).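

The step from compound 1 to compound 2 altered the ring and its attachment together, whereas this one changes only the ring on the oxygen on an aromatic ring, from cyclopentyl to cyclohexyl. In this assay that gives a 1.0-fold lower number from compound 2 to compound 3 (0.01 log units; within the scatter), so this swap of a five-membered for a six-membered carbon ring does not separate the two compounds. Nothing available explains this result. The compounds shown leave open whether a longer chain on the oxygen, or a group carrying an amine or a carboxylic acid, would move the number beyond the scatter.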